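Compound 4 and the ortho-substituted aryl question

The compounds below may be only part of what the source reports. "The series", "measured", "known", "first", "only" and "open" are said of these compounds alone.

In an assay for binding affinity to dual specificity mitogen-activated protein kinase kinase 4 (Homo sapiens), read by KINOMEscan, tested at 100 nM (on this read-out lower numbers stand for a stronger effect and higher numbers for a weaker effect at the one concentration tested), compound 1 `CCCS(=O)(=O)Nc1ccc(F)c(C(=O)c2n[nH]c3ncc(-c4cccc(OC)c4)cc23)c1F` gives 6.3% and stands second highest among the three measured compounds. Compound 3 `CCCS(=O)(=O)Nc1ccc(F)c(C(=O)c2n[nH]c3ncc(-c4cccc(N)c4)cc23)c1F` gives 1.6% in this assay, and compound 2 `CCCS(=O)(=O)Nc1ccc(F)c(C(=O)c2n[nH]c3ncc(-c4ccccc4N)cc23)c1F` gives 23%. Compound 4 `CCCS(=O)(=O)Nc1ccc(F)c(C(=O)c2n[nH]c3ncc(-c4ccc(OC)cc4Cl)cc23)c1F` has not yet been measured. It differs from compound 1 in one place: 2-chloro-4-methoxyphenyl in place of 3-methoxyphenyl on an aromatic carbon. Two measured steps speak to this change. The first, a number 4.7 percentage points lower from compound 1 to compound 3 (within the scatter), shows that exchanging the group on the 3-position of the phenyl ring leaves the read-out within the scatter. The second, a number 16.7 percentage points higher from compound 1 to compound 2 (beyond the scatter), shows that placing a substituent at the 2-position of the phenyl ring raises the number beyond the scatter, and a number 21.4 percentage points lower from compound 2 to compound 3 (beyond the scatter) confirms this reading. Because compound 2 gives 23% with a 2-substituent, compound 4 is expected to show a modest rise in this assay, a number 13.7 percentage points higher from compound 1 to compound 4 (beyond the scatter). The estimate for compound 4 is 20%, with a range from 5% to 45%.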

Compound 4, a percentage reported as activity, at one concentration (the size of the read-out at that concentration, not a potency): 5.3%
For compound 4 the middle estimate is 14.7 percentage points above the measured one; low and high end bracket the measured number.
By their numbers in this assay, from the lowest: compounds 3, 4 and 1 (each within the scatter of the next); then compound 2.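

In this assay, the 2-chloro-4-methoxyphenyl group of compound 4 reads level with the 3-methoxyphenyl group (a number 1 percentage points lower from compound 1 to compound 4 (within the scatter)) and with the 3-aminophenyl group (a number 3.7 percentage points higher from compound 3 to compound 4 (within the scatter)). It does not repeat the higher number given by the 2-aminophenyl group (a number 17.7 percentage points lower from compound 2 to compound 4 (beyond the scatter)), so among these compounds that higher number belongs to compound 2 alone, and this position on the shared core also takes the larger group of 9 heavy atoms with no step beyond the scatter from compound 1. Nothing available explains why the 2-chloro-4-methoxyphenyl and 2-aminophenyl groups part.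

The compounds shown do not separate the chlorine from the methoxy group, as neither a 2-chlorophenyl nor a 4-methoxyphenyl group stands among them. On these data alone, how a carboxylic acid or a morpholine on the phenyl ring would read in this assay also remains open.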